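This account rests on a few compounds, and the source may have more. Where it says the series, first, only, none or still open, it means among the compounds named here.

Compound 1 `Nc1nc2ccccc2c(=O)o1`, compound 2 `CNc1nc2ccccc2c(=O)o1` and compound 3 `Cc1ccccc1Nc1nc2ccccc2c(=O)o1` share one core and differ only in what sits on a nitrogen on an aromatic ring. In an assay on isolated protein for inhibition of complement C1r subcomponent (Homo sapiens) (on this read-out higher numbers stand for weaker inhibition and lower numbers for stronger inhibition), compound 1 reaches only the limit > 62500 nM. Compound 2 likewise gives only the limit > 62500 nM in this assay. Compound 3 gives a number, 31000 nM. The step from compound 1 to compound 2, a step that the two limits leave unreadable from compound 1 to compound 2, cannot be read because both sit at the limit of > 62500 nM in this assay, at which 2 of the 3 values shown sit. Compound 4 `O=c1oc(Nc2nncs2)nc2ccccc12` carries 1,3,4-thiadiazol-2-yl in place of methyl on a nitrogen on an aromatic ring. Among the measured compounds shown here, no measured step reads out, so the only guide is that compound 3, with an aromatic group on that nitrogen, gives a number at all. Compound 4 is therefore expected to come in near 30000 nM, with a likely range from 8000 nM to 100000 nM, which means an expected step of an at least 2.0-fold lower number from compound 2 to compound 4 (0.31 log units; beyond the scatter).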

Compound 4, half-maximal inhibitory concentration: > 62500 nM
Compound 4 ended at the assay's limit; the forecaster's own chance of this, stated with the estimate: 40%; at least 2.0-fold (0.31 log units) between middle value and limit.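

Compound 4 gives only a limit of the assay, so the steps to it from compound 1 and from compound 2 cannot be read: the limit of > 62500 nM in this assay, at which 3 of the 4 values shown sit.

In this assay the compounds shown leave open whether hydrogen, methyl and 1,3,4-thiadiazol-2-yl on that nitrogen differ at all.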